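A few compounds are considered here, and "the series" means these few. Any claim that something is new, unique, unknown or untested is made for them only; others in the source may bear on it.

Measured compounds, in a functional assay on HEK293 cells for antagonist activity at Voltage-dependent L-type calcium channel subunit alpha-1C (Oryctolagus cuniculus), read by FLIPR; a higher number here means a weaker inhibitor, a lower number a stronger inhibitor:
compound 1 `CCCCCOC(=O)C1=C(C)NC(C)=C(C(=O)OCC)C1c1cccc([N+](=O)[O-])c1` gives 49 nM
compound 2 `COC(=O)C1=C(C)NC(C)=C(C(=O)OC2C=CCCC2)C1c1cccc([N+](=O)[O-])c1` gives 10 nM
compound 3 `CCOC(=O)C1=C(C)NC(C)=C(C(=O)OCC)C1c1cccc(F)c1F` gives 15 nM

Compound 3 stands second highest of the three numbers in this assay. Its nearest neighbour is compound 2, whose number lies within the scatter of that of compound 3, so the two cannot be put in order. Compound 1 lies beyond the scatter from compound 3 and carries the higher number of that pair.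

Compound 4 `CCOC(=O)C1=C(C)NC(C)=C(C(=O)OCC)C1c1ccc(F)cc1F` is not yet measured. It differs from compound 3 in one place: 2,4-difluorophenyl in place of 2,3-difluorophenyl on a saturated ring carbon. The two share every other atom. Among the compounds with values here, no measured pair in this set isolates a shift of fluorine from one position of the aromatic ring to another, so the direction of the step has no direct precedent here. The expectation is a small step upward in this assay, of a size that may well stay inside the scatter, a 2.0-fold higher number from compound 3 to compound 4 (0.30 log units; within the scatter). Compound 4 is expected to give 30 nM, within a range from 8 nM to 120 nM.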

Compound 4, half-maximal inhibitory concentration: 20 nM
Compound 4: middle estimate off by 1.5-fold (0.18 log units), on the high side; the measured number falls inside the stated range.
By their numbers in this assay, from the lowest: compounds 2, 3 and 4 (each within the scatter of the next); then compound 1.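

In this assay, replacing 2,3-difluorophenyl with 2,4-difluorophenyl on the saturated ring carbon gives a 1.3-fold higher number from compound 3 to compound 4 (0.12 log units; within the scatter), so the two compounds cannot be put in order. Within the data shown here, this is the first pair in the set that differs in one place, and it shows that this rearrangement of the same atoms on the phenyl ring leaves the number within the scatter. Nothing measured here beyond these numbers bears on this step.

A single step says nothing about how a chlorine, a trifluoromethyl or a nitrile on this phenyl ring would behave at the same place. Compound 1 and compound 2 each differ from compound 3 in more than one place, so the contributions of their ester groups and of their nitro-bearing phenyl ring remain unseparated.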